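The source may report more compounds than this note shows. Statements on the series, on what has been measured and on what is new or still open speak of the compounds shown alone.

Compound 3 `c1ccc2c(C3CC(c4ccncc4)=NO3)c[nH]c2c1` is the bare form of the shared core. In a functional assay on CWR22R cells (Homo sapiens) for inhibition, read by MTT assay, with a stated time of 48 h (on this read-out higher numbers stand for weaker inhibition and lower numbers for stronger inhibition), compound 3 gives only > 100000 nM, a limit of the measurement rather than a number (the limit of > 100000 nM in this assay, at which 1 of the 3 values shown sits). Two substituted relatives are known. Compound 1 `Clc1ccc(Cn2cc(C3CC(c4ccncc4)=NO3)c3ccccc32)cc1` gives 9600 nM in this assay, and compound 2 `COc1ccc2c(C3CC(c4ccncc4)=NO3)c[nH]c2c1` gives 16300 nM. Removing the substituent produced an at least 10-fold higher number from compound 1 to compound 3 (1.01 log units; beyond the scatter) and an at least 6.1-fold higher number from compound 2 to compound 3 (0.78 log units; beyond the scatter), so each time the bare core was the weaker one. Compound 4 `Fc1ccc2c(C3CC(c4ccncc4)=NO3)c[nH]c2c1` differs from compound 3 by fluoro in place of hydrogen on an aromatic carbon, occupying the same ring position as the methoxy of compound 2. Since compound 2 gained modestly against the bare core, a smaller gain is expected here, an at least 1.6-fold lower number from compound 3 to compound 4 (0.22 log units; that floor lies within the scatter). Compound 4 is therefore estimated at 60000 nM, within 15000 nM to 150000 nM.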

Compound 4, half-maximal inhibitory concentration: 3660 nM
Estimate against measurement, compound 4: 16-fold (1.21 log units) above, outside the stated range (below it).
By their numbers in this assay, from the lowest: compound 4; then compounds 1 and 2 (each within the scatter of the next). At a limit, above all of these: compound 3.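

On this ring position, the identity of the group matters as well as its presence. In this assay, a single fluorine atom gives an at least 27-fold lower number from compound 3 to compound 4 (1.43 log units; beyond the scatter), and fluoro also outperforms methoxy, with a 4.5-fold lower number from compound 2 to compound 4 (0.65 log units; beyond the scatter). Compound 3 stands at a limit rather than a number, so the first step has only a floor, because its true size cannot be read: the limit of > 100000 nM in this assay, at which 1 of the 4 values shown sits.

Only fluoro and methoxy are shown here, so no trend across groups can be drawn, and a nitrile or an amine at this position remains open. Also open, as far as these compounds go, is whether fluoro adds to the 4-chlorobenzyl of compound 1 on the aromatic nitrogen.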